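A few compounds are considered here, and "the series" means these few. Any claim that something is new, unique, unknown or untested is made for them only; others in the source may bear on it.

Compound 1 `O=C(CCCCCCNC(=O)C(O)(O)C(F)(F)F)Nc1nc2ccc(Cl)cc2s1`: 11000 nM
Compound 2 `O=C(CCCCCCNC(=O)C(O)(O)C(F)(F)F)Nc1ccc(-c2ccccc2)cc1`: 4730 nM
Compound 3 `O=C(CCCCCCNC(=O)C(O)(O)C(F)(F)F)Nc1nc2ccc(F)cc2s1`: 6470 nM

All three compounds were tested in a functional assay on HCT-116 cells (Homo sapiens) for inhibition, read by colorimetric assay, with a stated time of 3 days; on this read-out lower numbers stand for stronger inhibition and higher numbers for weaker inhibition. Compound 3, at 6470 nM, holds the middle of the three numbers, and it lies within the scatter of both compound 1 and compound 2. Compound 4 `O=C(CCCCCCNC(=O)C(O)(O)C(F)(F)F)Nc1nc2ccc(Br)cc2s1` keeps the core and chain of compound 3 and differs at one place, with bromo in place of fluoro on an aromatic carbon. Among the measured compounds shown here, only one measured step bears on this change, a 1.7-fold lower number from compound 1 to compound 3 (0.23 log units; within the scatter), with fluoro in place of chloro on an aromatic carbon, and it stays within the scatter. No halogen swap on this core has yet been shown to move the number beyond the scatter, so no clear step is expected in this assay here, with only a slight lean towards the number of compound 1 at 11000 nM. The expected change is a 1.5-fold higher number from compound 3 to compound 4 (0.17 log units; within the scatter). Compound 4 is estimated at 9500 nM, with an expected range of 4500 nM to 20000 nM.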

Compound 4, half-maximal inhibitory concentration: 10300 nM
The estimate for compound 4 lay 1.1-fold (0.04 log units) below the measured number; the measured number falls inside the stated range.
By their numbers in this assay, from the lowest: compounds 2, 3, 4 and 1 (each within the scatter of the next, the first and the last beyond it).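

With bromo now on this aromatic carbon, the shared core carries three halogens, and in this assay the new compound gives a 1.6-fold higher number from compound 3 to compound 4 (0.20 log units; within the scatter) and a 1.1-fold lower number from compound 1 to compound 4 (0.03 log units; within the scatter) as its two steps. Together with the earlier swap of chloro for fluoro, this means that no pair among fluoro, chloro and bromo at this place lies beyond the scatter, so this read-out does not separate these three halogens. No measurement at hand offers an explanation for this result.

From the compounds shown here alone, whether a group other than a halogen at this place, such as a methoxy group, an amine or a nitrile, would move the number beyond the scatter remains open. So does the effect of a longer chain or a shorter chain on the same core.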